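This account rests on a few compounds, and the source may have more. Where it says the series, first, only, none or still open, it means among the compounds named here.

Of the compounds shown here, three from this series have been measured in a functional assay on MKN-45 cells (Homo sapiens) for inhibition, read by MTT assay; on this read-out lower numbers stand for stronger inhibition and higher numbers for weaker inhibition. Compound 1 `N#Cc1c(N)sc(C(=O)Nc2ccc(Cl)cc2)c1-c1ccccc1` gives 420 nM in this assay. Compound 2 `N#CCC(=O)Nc1sc(C(=O)Nc2ccc(Cl)cc2)c(-c2ccccc2)c1C#N` differs from compound 1 only by the change (hydrogen in place of (cyanomethyl)carbonyl on a nitrogen on an aromatic ring), and in this assay compound 2 gives 590 nM. The step of a 1.4-fold lower number from compound 2 to compound 1 (0.15 log units; within the scatter) is small. Compound 3 `CCOC(=O)c1c(NC(=O)CC#N)sc(C(=O)Nc2ccccc2)c1-c1ccccc1` carries a different core; how its core differs from that of compound 2 is not broken down here. In this assay compound 3 gives 590 nM, level with compound 2 at the digits shown and within the scatter of compound 1.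

Compound 4 `CCOC(=O)c1c(N)sc(C(=O)Nc2ccccc2)c1-c1ccccc1` has not yet been measured. It differs from compound 3 by hydrogen in place of (cyanomethyl)carbonyl on a nitrogen on an aromatic ring, the same change that leads from compound 2 to compound 1, made at the same kind of place on the core of compound 3. Because the step of a 1.4-fold lower number from compound 2 to compound 1 (0.15 log units; within the scatter) stayed within the scatter, a comparably small step is expected from compound 3 to compound 4, namely a 1.3-fold lower number from compound 3 to compound 4 (0.12 log units; within the scatter). Compound 4 is therefore estimated at 450 nM in this assay, with a likely range from 200 nM to 1000 nM.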

Compound 4, half-maximal inhibitory concentration: 8090 nM
For compound 4 the middle estimate is 18-fold (1.25 log units) below the measured one; measured number outside the range, above it.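

In this assay, the new step is a 14-fold higher number from compound 3 to compound 4 (1.14 log units; beyond the scatter), whereas the same change on the other core gave a 1.4-fold lower number from compound 2 to compound 1 (0.15 log units; within the scatter). Replacing the (cyanomethyl)carbonyl group on this nitrogen with hydrogen therefore did not have a comparable outcome on the two cores: the same change on two cores in this assay, a 1.4-fold lower number (0.15 log units; within the scatter) from compound 2 to compound 1 and a 14-fold higher number (1.14 log units; beyond the scatter) from compound 3 to compound 4, 19-fold (1.28 log units) apart, beyond the scatter of two such steps This shows that the size of the step cannot be carried from one of these cores to the other, but it does not show which feature of the cores sets the two outcomes apart, nor how the change would behave on any further core.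

The compounds shown leave open whether other groups on the same nitrogen, such as an acetyl group or a longer acyl chain, would give numbers close to that of compound 3 or close to that of compound 4. Also open, on these data alone, is how the same change would turn out on a core carrying a carboxylic acid.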